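The source may hold more compounds than are shown below. What is called first, only, known or untested is meant among the compounds shown, and "the series" means these compounds.

Compound 1 `CCN1CCCC1CNC(=O)c1cc(N(C)S(=O)(=O)N(C)C)ccc1OC` is examined in a functional assay on the whole organism for inhibition, with Mus musculus as the target (a lower number here means that less compound is needed, a higher number that more compound is needed for the effect), where compound 1 gives 36.2 mg/kg. Compound 2 `CCN1CCCC1CNC(=O)c1cc(N(C)S(=O)(=O)N(C)C)c(C)cc1OC` differs from compound 1 by methyl in place of hydrogen on an aromatic carbon. In this assay compound 2 reaches only a limit, > 50 mg/kg. The step is an at least 1.3-fold higher number from compound 1 to compound 2 (0.14 log units; that floor lies within the scatter). Compound 3 `CCN1CCCC1CNC(=O)c1cc(NS(=O)(=O)NC)ccc1OC` differs from compound 1 by (methylsulfamoyl)amino in place of (dimethylsulfamoyl)(methyl)amino on an aromatic carbon. In this assay compound 3 likewise stops at a limit, > 50 mg/kg. The step is an at least 1.3-fold higher number from compound 1 to compound 3 (0.14 log units; that floor lies within the scatter), with the limit of > 50 mg/kg in this assay, at which 2 of the 3 values shown sit, the only thing that can be said about it. Compound 4 `CCN1CCCC1CNC(=O)c1cc(NS(=O)(=O)NC)c(C)cc1OC` differs from compound 3 by methyl in place of hydrogen on an aromatic carbon, the same kind of change as from compound 1 to compound 2, though here the methyl enters ortho to a (methylsulfamoyl)amino group rather than ortho to a (dimethylsulfamoyl)(methyl)amino group. For compound 4 a step that the limit leaves unreadable from compound 3 to compound 4 is expected, because the same kind of change gave an at least 1.3-fold higher number from compound 1 to compound 2 (0.14 log units; that floor lies within the scatter) and compound 3 itself already sits at a limit. Compound 4 is therefore estimated at 80 mg/kg.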

Compound 4, dose for half-maximal effect: > 50 mg/kg
Compound 4: a limit, no number; the forecaster's own chance of this, stated with the estimate: 85%; the middle value is on the limit's open side.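

Neither the step from compound 3 to compound 4 nor the step from compound 2 to compound 4 can be read, since each compares two limits: the limit of > 50 mg/kg in this assay, at which 3 of the 4 values shown sit.

The compounds shown leave open how compound 2, compound 3 and compound 4 differ from one another in this assay.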